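Methylsulfanyl for aminoamino on the shared core

The source may report more compounds than this note shows. Statements on the series, on what has been measured and on what is new or still open speak of the compounds shown alone.

Measured so far:
compound 1, `COc1ccc(-c2nc(SC)n(C)c(=O)c2C#N)cc1`: 73 ug/mL
compound 2, `CN(C)c1ccc(-c2nc(NN)n(C)c(=O)c2C#N)cc1`: 69 ug/mL

In a functional assay, with a stated time of 150 min (on this read-out higher numbers stand for weaker inhibition and lower numbers for stronger inhibition), compound 1 gives 73 ug/mL and compound 2 gives 69 ug/mL. Going by the values given here, compound 2 stands within the scatter of compound 1 on this assay; the two numbers cannot be told apart, and since the two compounds differ in two places no single step between them can be read.

Compound 3, `CSc1nc(-c2ccc(N(C)C)cc2)c(C#N)c(=O)n1C`, is not yet measured. It differs from compound 2 by methylsulfanyl in place of aminoamino on an aromatic carbon. Compound 1 already carries a methylsulfanyl group on its core and falls in the same range as compound 2, so no step beyond the scatter is expected in this assay for this exchange. The estimated step of a 1.0-fold higher number from compound 2 to compound 3 (0.01 log units; within the scatter) is expected to stay inside the scatter. For compound 3 the expected value in this assay is 70 ug/mL, with a range from 35 ug/mL to 140 ug/mL.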

Compound 3, half-maximal inhibitory concentration: 93 ug/mL
Compound 3: middle estimate off by 1.3-fold (0.12 log units), on the low side; the measured number falls inside the stated range.
By their numbers in this assay, from the lowest: compounds 2, 1 and 3 (each within the scatter of the next).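

In this assay, the exchange at the aromatic carbon between two ring nitrogen atoms can now be read as a single change: methylsulfanyl in place of aminoamino gives a 1.3-fold higher number from compound 2 to compound 3 (0.13 log units; within the scatter). Removing the hydrogen-bond donors of aminoamino at this position therefore produces no step beyond the scatter on this read-out. The second single change, dimethylamino in place of methoxy on an aromatic carbon, gives a 1.3-fold higher number from compound 1 to compound 3 (0.11 log units; within the scatter), so neither exchange separates the compounds, and no measurement is available to speak to the reason.

On these data alone, whether a different group at this position, such as a carboxylic acid, a primary amine or a longer chain, would give a step beyond the scatter remains open. Going by these compounds alone, with all three compounds within the scatter of one another, the series so far holds no step beyond the scatter.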